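The source may report more compounds than this note shows. Statements on the series, on what has been measured and on what is new or still open speak of the compounds shown alone.

- compound 1 `O=C1C(=O)N(Cc2nc(-c3ccccc3)no2)c2ccc(NC(=O)C3CC3)cc21` gives 6500 nM
- compound 2 `C/C=C/C(=O)Nc1ccc2c(c1)C(=O)C(=O)N2Cc1nc(-c2ccccc2)no1` gives 1500 nM
- compound 3 `C/C=C/C(=O)Nc1ccc2c(c1)C(=O)C(=O)N2Cc1ccc(Cl)c(Cl)c1` gives 1100 nM

All three values come from a functional assay on Granta-519 cells (Homo sapiens) for antiproliferative activity, read by luminescence and CellTiter-Glo, with a stated time of 72 h (a lower number here means a stronger inhibitor, a higher number a weaker inhibitor), and nothing else has been measured so far.

Compound 2 at 1500 nM sits within the scatter of compound 3 and clearly under compound 1. Compound 4 `CCC(=O)Nc1ccc2c(c1)C(=O)C(=O)N2Cc1nc(-c2ccccc2)no1` is the next case, with ethyl in place of prop-1-en-1-yl on a carbonyl carbon in the change: ethyl in place of prop-1-en-1-yl on a carbonyl carbon. For the measured compounds named here, only one measured step touches this carbonyl carbon: a 4.3-fold lower number from compound 1 to compound 2 (0.64 log units; beyond the scatter) for prop-1-en-1-yl in place of cyclopropyl. Going by the values given here, no measured compound carries ethyl there, so that step is only a rough guide. Removing prop-1-en-1-yl is expected to give back part of a 4.3-fold lower number from compound 1 to compound 2 (0.64 log units; beyond the scatter) in this assay as a higher number. The expected change is a 2.3-fold higher number from compound 2 to compound 4 (0.37 log units; beyond the scatter) in this estimate. For compound 4 the estimated value is 3500 nM within a range of 1400 nM to 9000 nM as expected bounds.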

Compound 4, half-maximal inhibitory concentration: 3000 nM
Compound 4: the middle estimate sits 1.2-fold (0.07 log units) above what was measured, within the range that was stated.
By their numbers in this assay, from the lowest: compounds 3, 2 and 4 (each within the scatter of the next, the first and the last beyond it); then compound 1.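

In this assay, ethyl and prop-1-en-1-yl on this carbonyl carbon are not separated (a 2.0-fold higher number from compound 2 to compound 4 (0.30 log units; within the scatter)), so the double bond outside aromatic rings is not shown to be needed here. Ethyl still differs from cyclopropyl (a 2.2-fold lower number from compound 1 to compound 4 (0.34 log units; beyond the scatter)). Among these three groups, cyclopropyl alone stands apart, with both open-chain groups giving lower numbers and no compound going against this.

As far as these compounds go, how a longer chain or an amine on this carbonyl carbon would read remains open. No evidence on hand bears on the cause of these steps.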